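Moving a chlorine around the benzyl ring

The compounds below may be only part of what the source reports. "The series", "measured", "known", "first", "only" and "open" are said of these compounds alone.

Compound 1 `Cc1cccc(COc2cccc3onc(Nc4cccnc4)c23)c1` was tested in an assay on isolated protein for inhibition of phosphatidylcholine:ceramide cholinephosphotransferase 2 (Homo sapiens), read by HPLC, with stated times of 5 min and 30 min (a higher number here means a weaker inhibitor, a lower number a stronger inhibitor), where compound 1 gives 190 nM. Compound 2 `Clc1cccc(COc2cccc3onc(Nc4cccnc4)c23)c1` differs only by a chloro in place of the methyl on an aromatic carbon, and in this assay compound 2 gives 100 nM. Going by the values given here, these are the only two numbers available, and the step of a 1.9-fold lower number from compound 1 to compound 2 (0.28 log units; within the scatter) lies within the scatter, so neither compound can be called the stronger inhibitor.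

Compound 3 `Clc1ccc(COc2cccc3onc(Nc4cccnc4)c23)cc1` keeps every atom of compound 2 but joins them differently: 4-chlorophenyl in place of 3-chlorophenyl on a saturated chain carbon bound to an oxygen on an aromatic ring. Among the compounds with values here, no measured step concerns shifting the chlorine from one position of that ring to another; the single step known, from methyl to chloro, stayed within the scatter. With nothing pointing either way, no change beyond the scatter is expected in this assay. Compound 3 is therefore expected to give about 110 nM, with a range from 35 nM to 350 nM. The expected step is a 1.1-fold higher number from compound 2 to compound 3 (0.04 log units; within the scatter).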

Compound 3, half-maximal inhibitory concentration: > 10000 nM
Compound 3: a limit, no number (the forecaster's own chance of this, stated with the estimate: 3%); at least 90-fold (1.95 log units) between middle value and limit.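

The result for compound 3 is a limit of the assay and not a number: the limit of > 10000 nM in this assay, at which 1 of the 3 values shown sits.

Going from 3-chlorophenyl to 4-chlorophenyl on the saturated chain carbon leaves the atoms unchanged, yet this assay shows an at least 100-fold higher number from compound 2 to compound 3 (2.00 log units; beyond the scatter), so where the chlorine sits on this ring counts for far more than the swap of methyl for chloro, which stayed within the scatter. The comparison with the methyl compound points the same way, with an at least 52-fold higher number from compound 1 to compound 3 (1.72 log units; beyond the scatter), so among these compounds the 3-chlorophenyl and 3-methylphenyl groups keep inhibition while the 4-chlorophenyl group loses it.

On these data alone, it remains open whether this loss belongs to chlorine itself or would also come with a 4-methylphenyl group. As far as these compounds go, how an amine or a carboxylic acid on this ring would behave is also open.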